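A few compounds are considered here, and "the series" means these few. Any claim that something is new, unique, unknown or untested is made for them only; others in the source may bear on it.

Compound 1 `CCCCN(C)c1nc(C(C)(C)C)ccc1CNC(=O)C(C)c1ccc(NS(C)(=O)=O)c(F)c1`: 1.2 nM
Compound 2 `CC(C(=O)NCc1ccc(C(C)(C)C)nc1OC1CCCCC1)c1ccc(NS(C)(=O)=O)c(F)c1`: 2.5 nM
Compound 3 `CC(C(=O)NCc1ccc(C(C)(C)C)nc1OCc1ccc(F)cc1)c1ccc(NS(C)(=O)=O)c(F)c1`: 0.8 nM

In an assay on cells for antagonist activity at transient receptor potential cation channel subfamily V member 1 (Homo sapiens), read by FLIPR and calcium flux, with a stated time of 6 min (a lower number here means a stronger inhibitor, a higher number a weaker inhibitor), compound 3 gives the lowest of the three numbers. One of its gaps is a 1.5-fold lower number from compound 1 to compound 3 (0.18 log units; within the scatter), so that pair cannot be ordered; the other gap is a 3.1-fold lower number from compound 2 to compound 3 (0.49 log units; beyond the scatter), which lies beyond the scatter. Compound 4 `CCCCCc1nc(C(C)(C)C)ccc1CNC(=O)C(C)c1ccc(NS(C)(=O)=O)c(F)c1` differs from compound 3 in one place: pentyl in place of (4-fluorobenzyl)oxy on an aromatic carbon. Going by the values given here, two measured steps touch the same aromatic carbon. The step of a 1.5-fold lower number from compound 1 to compound 3 (0.18 log units; within the scatter) exchanges one large group for another without leaving the scatter, while the step of a 3.1-fold lower number from compound 2 to compound 3 (0.49 log units; beyond the scatter) shows that swapping cyclohexyl for 4-fluorobenzyl moves the number modestly. Among the compounds with values here, a pentyl chain with no ring has no direct precedent among the three measured compounds, so the direction is uncertain; the spread across compounds 1, 2 and 3 suggests nothing larger than a modest rise. The expected step is a 2.5-fold higher number from compound 3 to compound 4 (0.40 log units; beyond the scatter), and compound 4 is estimated at 2 nM with a range of 0.7 nM to 6 nM in this assay.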

Compound 4, inhibition constant: 1.9 nM
Compound 4: the middle estimate sits 1.1-fold (0.02 log units) above what was measured, within the range that was stated.
By their numbers in this assay, from the lowest: compounds 3, 1, 4 and 2 (each within the scatter of the next, the first and the last beyond it).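

In this assay, a pentyl chain on this aromatic carbon, with no ring and no hydrogen-bond acceptor, cannot be told apart from the two larger groups in a 1.3-fold lower number from compound 2 to compound 4 (0.12 log units; within the scatter) and in a 1.6-fold higher number from compound 1 to compound 4 (0.20 log units; within the scatter), so neither a ring nor a linking oxygen or nitrogen is needed to stay in the range of those compounds. Only a 2.4-fold higher number from compound 3 to compound 4 (0.38 log units; beyond the scatter) lies beyond the scatter, and this modest step makes (4-fluorobenzyl)oxy the only group shown that separates from pentyl at this position. No available evidence accounts for this difference.

Still open, going by these compounds, is whether a longer chain such as heptyl, or a pentyl chain ending in an amine or a carboxylic acid, would stay in this range. A small methyl group at the same carbon would test how much of the substituent is needed at all.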